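The compounds below may be only part of what the source reports. "The series", "measured", "known", "first", "only" and "open" are said of these compounds alone.

Measured compounds in an ADME assay on MT4 cells (Homo sapiens) for cytotoxicity, read by MTT assay, with a stated time of 4 days; a lower number here means that less compound is tolerated, a higher number that more compound is tolerated:

Compound 1, `Cc1ccc(NC(=O)CS(=O)(=O)c2nccc(Oc3c(C)cc(C#N)cc3C)n2)cc1C`, gives 13900 nM.
Compound 2, `COc1ccc(NC(=O)CS(=O)(=O)c2nccc(Oc3c(C)cc(C#N)cc3C)n2)cc1`, gives 5110 nM.
Compound 3, `Cc1cc(C#N)cc(C)c1Oc1ccnc(S(=O)(=O)CC(=O)Nc2ccc(Cl)cc2)n1`, gives 16600 nM.

Compound 1 stands second highest of the three numbers in this assay. Its nearest neighbour is compound 3, reached by a 1.2-fold higher number from compound 1 to compound 3 (0.08 log units; within the scatter), a step within the scatter. Its furthest is compound 2, reached by a 2.7-fold lower number from compound 1 to compound 2 (0.43 log units; beyond the scatter), a modest step beyond the scatter. Between compound 2 and compound 3 the change of chloro in place of methoxy gives a 3.2-fold higher number from compound 2 to compound 3 (0.51 log units; beyond the scatter).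

The unmeasured compound 4, `Cc1cc(C#N)cc(C)c1Oc1ccnc(S(=O)(=O)CC(=O)Nc2ccc(Br)cc2)n1`, differs from compound 1 as follows: 4-bromophenyl in place of 3,4-dimethylphenyl on an amide-type nitrogen.

Within the data shown here, the step that bears most directly on this change is the one from compound 1 to compound 3, where 4-chlorophenyl replaced the same 3,4-dimethylphenyl on the amide-type nitrogen and the number stayed within the scatter. The 4-bromophenyl of compound 4 is the closest structural relative of that 4-chlorophenyl among the groups here, so the step expected in this assay is none beyond the scatter, with no clear direction. Compound 4 is therefore estimated at 15000 nM, within a range of 7000 nM to 32000 nM, which corresponds to an expected step of a 1.1-fold higher number from compound 1 to compound 4 (0.03 log units; within the scatter).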

Compound 4, half-maximal cytotoxic concentration: 15600 nM
For compound 4 the middle estimate is 1.0-fold (0.02 log units) below the measured one; the measured number falls inside the stated range.
By their numbers in this assay, from the lowest: compound 2; then compounds 1, 4 and 3 (each within the scatter of the next).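

In this assay, a second halogen on the amide-type nitrogen's phenyl behaves like the first: 4-bromophenyl in place of 3,4-dimethylphenyl gives a 1.1-fold higher number from compound 1 to compound 4 (0.05 log units; within the scatter) and bromo in place of chloro gives a 1.1-fold lower number from compound 3 to compound 4 (0.03 log units; within the scatter) so that compounds 1, 3 and 4 form one group within the scatter. The separation of compound 2 also recurs with this new halogen, since bromo in place of methoxy gives a 3.1-fold higher number from compound 2 to compound 4 (0.48 log units; beyond the scatter) and compound 2 remains the only one of the four whose number stands apart from the others. Nothing measured here accounts for why the methoxy compound differs from the two halogen compounds and the dimethyl compound.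

The compounds shown leave open whether this grouping would hold for a phenyl carrying fluoro, an amine or a carboxylic acid in place of the bromo. They also leave open whether the same tolerance of these aryl changes would persist if the nitrile or the sulfonyl link in the shared core were replaced, as both stay the same throughout.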